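This account rests on a few compounds, and the source may have more. Where it says the series, first, only, none or still open, it means among the compounds named here.

Measured in an in vitro ADME assay on microsomes from liver (Homo sapiens) for metabolic stability, read by LC-MS; a lower number here means that the compound disappears faster, a higher number that the compound lasts longer:
compound 1 `CCc1ccc(NC(=O)N2CCCN(C(=O)CCC3CCCC3)CC2)cc1` — 0.0833 h
compound 2 `CC(C)(C)c1cc(NC(=O)N2CCCN(C(=O)C3CCOCC3)CC2)no1` — > 2 h, a limit of the assay, not a number
compound 3 `CC(C)(C)c1cc(NC(=O)N2CCCN(C(=O)C3CCOCC3)CC2)on1` — > 2 h, likewise a limit of the assay

Compound 3 thus stands at the limit of this assay. Compound 2 sits at the same limit, so the step that the two limits leave unreadable from compound 2 to compound 3 cannot be sized; this is the situation described by the limit of > 2 h in this assay, at which 2 of the 3 values shown sit. Compound 1 alone gives a read number.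

Compound 4 `CC(C)(C)c1cnc(NC(=O)N2CCCN(C(=O)C3CCOCC3)CC2)s1` carries a group of 9 heavy atoms (7 carbon, 1 nitrogen, 1 sulfur; one five-membered aromatic ring with 2 hetero atoms) in place of a group of 9 heavy atoms (7 carbon, 1 nitrogen, 1 oxygen; one five-membered aromatic ring with 2 hetero atoms), on an amide-type nitrogen. Among the compounds with values here, no measured step concerns this exchange of ring heteroatoms, and the one measured step is unreadable, so no direction can be taken from the series. Compound 4 is expected to remain close to the limit, the estimated step being an at least 1.3-fold lower number from compound 3 to compound 4 (0.12 log units; that floor lies within the scatter). Compound 4 is estimated at 1.5 h, in the range 0.5 h to 4 h.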

Compound 4, half-life: 0.45 h
Beside the measured number, compound 4's estimate is 3.3-fold (0.52 log units) above it; measured number below the stated range.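

In this assay, this place on the amide-type nitrogen proves sensitive to the ring itself: exchanging the oxygen-bearing group for the sulfur-bearing one gives an at least 4.4-fold lower number from compound 3 to compound 4 (0.64 log units; beyond the scatter), and the same exchange gives an at least 4.4-fold lower number from compound 2 to compound 4 (0.64 log units; beyond the scatter). The tert-butyl group is present throughout, so a change in the five-membered aromatic ring alone is enough to bring the half-life down to a readable number. Both steps are floors only, since each starts from a limit of the assay: the limit of > 2 h in this assay, at which 2 of the 4 values shown sit.

From the compounds shown here alone, the step between compound 2 and compound 3 cannot be read, so any difference between the two oxygen-bearing groups stays open. Also open, going by these compounds, is whether the sulfur atom or the altered ring arrangement accounts for the drop, and how an amine in place of the tert-butyl group would fare.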